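The compounds below may be only part of what the source reports. "The series", "measured", "known", "first", "only" and "open" are said of these compounds alone.

Two compounds of a shared core carrying a propoxy-linked piperazine have been measured in an assay on isolated protein for binding affinity to histamine H2 receptor (Homo sapiens); on this read-out higher numbers stand for weaker inhibition and lower numbers for stronger inhibition. Compound 1 `CCCCCC(=O)c1ccc(OCCCN2CCN(C(=O)C(C)C)CC2)cc1`, which bears a pentyl chain on the carbonyl and an isobutyryl group on the piperazine, gives 29500 nM in this assay. Compound 2 `CCCCCCCCC(=O)c1ccc(OCCCN2CCN(C(=O)OCC)CC2)cc1`, with an octyl chain on the carbonyl and an ethyl carbamate on the piperazine, gives 2690 nM, the lowest of the two numbers; compound 1 stands at a higher number, and the gap between the two lies beyond the scatter. The two compounds differ in two places at once, so no single step can be read from them.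

Compound 3 `CCOC(=O)N1CCN(CCCOc2ccc(C(=O)c3ccc(OC)cc3)cc2)CC1` keeps the ethyl carbamate of compound 2 and differs from it in one place only: 4-methoxyphenyl in place of octyl on a carbonyl carbon. Within the data shown here, no measured pair shows the effect of such an exchange on the carbonyl carbon. Compound 3 is expected to give a higher number than compound 2, a step of a 3.0-fold higher number from compound 2 to compound 3 (0.47 log units; beyond the scatter) that is estimated to lie beyond the scatter, though with wide uncertainty. The estimate for compound 3 is 8000 nM, within a range from 1500 nM to 40000 nM.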

Compound 3, inhibition constant: 8320 nM
Compound 3: middle estimate off by 1.0-fold (0.02 log units), on the low side, and the stated range covers the measured number.
By their numbers in this assay, from the lowest: compound 2; then compound 3; then compound 1.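

Among these compounds, with the ethyl carbamate held fixed, the exchange of octyl for 4-methoxyphenyl on a carbonyl carbon gives in this assay the first step that can be read from these compounds: a 3.1-fold higher number from compound 2 to compound 3 (0.49 log units; beyond the scatter) shows that this position alone can move the number beyond the scatter. The gap between compound 1 and compound 2 could not show this, as those two differ in two places at once. The step also shows that the open chain can give way to an aromatic ring bearing a hydrogen-bond acceptor, with the same count of heavy atoms, at a modest cost in the direction of a higher number, though nothing available bears on why the number moves this way.

One step cannot separate the part played by the ring from that of the methoxy group, so a plain phenyl or a longer chain on the same carbonyl carbon would be needed to tell them apart. As far as these compounds go, it also remains open whether the exchange would give a step of similar size with the isobutyryl group on the piperazine in place of the ethyl carbamate.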